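Aryl exchange from compound 2 to compound 3

The source may report more compounds than this note shows. Statements on the series, on what has been measured and on what is new or still open speak of the compounds shown alone.

In an ADME assay on HEK293 cells (Homo sapiens) for cytotoxicity, read by MTT assay, with a stated time of 48 h (on this read-out lower numbers stand for stronger inhibition and higher numbers for weaker inhibition), compound 2 `C=C1CCC[C@]2(C)CCC(c3cn(-c4ccc(I)cc4)nn3)=CC[C@@]12C` gives 215000 nM and compound 1 `C=C1CCC[C@]2(C)CCC(c3cn(-c4ccc(OC)cc4)nn3)=CC[C@@]12C` gives 410000 nM, which places the two within the scatter of each other. Compound 3 `C=C1CCC[C@]2(C)CCC(c3cn(-c4cccc(OC)c4)nn3)=CC[C@@]12C` has not yet been measured. The change is 3-methoxyphenyl in place of 4-iodophenyl on an aromatic nitrogen, with 3-methoxyphenyl in place of 4-iodophenyl on an aromatic nitrogen. Among the compounds with values here, the one measured step bearing on it is a 1.9-fold lower number from compound 1 to compound 2 (0.28 log units; within the scatter), an exchange of methoxy for iodo on an aromatic carbon that stays within the scatter. Within the data shown here, no measured compound shows what the 3-methoxyphenyl group does in place of the 4-methoxyphenyl group of compound 1. No step beyond the scatter is therefore expected in this assay, and no firm direction. The estimated step is a 1.4-fold higher number from compound 2 to compound 3 (0.14 log units; within the scatter). For compound 3 the expected value is 300000 nM, with an estimated range of 140000 nM to 650000 nM.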

Compound 3, half-maximal inhibitory concentration: 734000 nM
For compound 3 the middle estimate is 2.4-fold (0.39 log units) below the measured one; the whole stated range lies below it.
By their numbers in this assay, from the lowest: compounds 2, 1 and 3 (each within the scatter of the next, the first and the last beyond it).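

In this assay, within the data shown here, the exchange on the aromatic nitrogen gives the first step that clears the scatter, a 3.4-fold higher number from compound 2 to compound 3 (0.53 log units; beyond the scatter), so the aryl group at this place can shift the read-out measurably. The step between the two methoxyphenyl isomers, a 1.8-fold higher number from compound 1 to compound 3 (0.25 log units; within the scatter), stays within the scatter, so these compounds do not separate 3-methoxyphenyl from 4-methoxyphenyl. Compound 1 lies within the scatter of both compound 2 and compound 3, so only the two ends of the series are distinct, and that pair differs in both the substituent and where it sits on the phenyl ring.

Going by these compounds, it remains open whether 3-iodophenyl would stay with compound 2 or move towards compound 3. On these data alone, the effect of an amine or a carboxylic acid on the phenyl ring is also open. No measurement at hand accounts for the step from 4-iodophenyl to 3-methoxyphenyl.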